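Swapping a Fluorophenyl for a Chlorophenyl: Cytotoxicity Outlook

This account rests on a few compounds, and the source may have more. Where it says the series, first, only, none or still open, it means among the compounds named here.

Compound 1 `Cn1c(-c2ccc(F)cc2)cnc1NC(=O)c1ccc(F)cc1` is the starting point. In a toxicity assay on THP-1 cells (Homo sapiens) for inhibition (a lower number here means that less compound is tolerated, a higher number that more compound is tolerated), compound 1 gives > 100000 nM, which is a limit of the assay rather than a measured number. Compound 2 `Cn1c(-c2ccc([N+](=O)[O-])cc2)cnc1NC(=O)c1ccc(F)cc1` carries a nitro in place of fluoro on an aromatic carbon. In this assay compound 2 gives > 50000 nM, again a limit. The step that the two limits leave unreadable from compound 1 to compound 2 therefore cannot be sized, as the limit of > 100000 nM in this assay, at which 1 of the 2 values shown sits, and the limit of > 50000 nM in this assay, at which 1 of the 2 values shown sits, show. Compound 3 `Cn1c(-c2cccc(Cl)c2)cnc1NC(=O)c1ccc(F)cc1` is the compound not yet measured. It differs from compound 1 by 3-chlorophenyl in place of 4-fluorophenyl on an aromatic carbon. Among the compounds with values here, no measured step changes the same group, so the only guidance is that both measured compounds sit at a limit, with no readable direction between them. A step beyond the scatter is not expected in this assay, in either direction. For compound 3 the expected value in this assay is estimated at 100000 nM, with a range from 30000 nM to 300000 nM, and the result will most likely again be reported only as a limit. That expectation corresponds to an estimated step of a number no higher from compound 1 to compound 3 (the limit leaves the size open).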

Compound 3, half-maximal cytotoxic concentration: > 50000 nM
Compound 3 gave a limit, no number; the forecaster's own chance of this, stated with the estimate: 75%; the middle value is on the limit's open side.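

In this assay compound 3 gives > 50000 nM, which is a limit and not a number. Within the data shown here, compound 1 also stands at a limit, so no step between compound 1 and compound 3 can be read. The compounds shown leave open at what concentration any of them harms these cells, and whether 3-chlorophenyl in place of 4-fluorophenyl changes that concentration.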